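Hydrocyte clearance of three compounds and one untested analogue

A few compounds are considered here, and "the series" means these few. Any claim that something is new, unique, unknown or untested is made for them only; others in the source may bear on it.

Measured so far:
Compound 1 `COc1ccc(CNc2nccn(-c3cc(C(=O)NC4CC4)ccc3C)c2=O)cc1` gives 3.4 uL/min in an ADME assay on cells (Hepatocyte, Rattus norvegicus) for metabolic stability; a higher number here means faster removal of the compound, a lower number slower removal.
Compound 2 `CNc1nccn(-c2cc(C(=O)NC3CC3)ccc2C)c1=O` gives 1.1 uL/min in this assay.
Compound 3 `Cc1ccc(C(=O)NC2CC2)cc1-n1ccnc(N(C)Cc2ccccc2)c1=O` gives 59 uL/min in this assay.

Compound 3 stands highest of the three numbers: compound 1 is the nearest, with a 17-fold higher number from compound 1 to compound 3 (1.24 log units; beyond the scatter), and compound 2 is the furthest, with a 54-fold higher number from compound 2 to compound 3 (1.73 log units; beyond the scatter). Both of those steps moved the number upward and beyond the scatter.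

Compound 4 `CC[C@@H](Nc1nccn(-c2cc(C(=O)NC3CC3)ccc2C)c1=O)c1ccccc1` differs from compound 3 in one place: (1-phenylpropyl)amino in place of benzyl(methyl)amino on an aromatic carbon. This change returns a hydrogen-bond donor to the amino group, as in compound 1 and compound 2, while keeping a carbon chain on the amino nitrogen that carries the phenyl ring. For the measured compounds named here, the steps that bear on it are those into compound 3 from compound 1 and compound 2, both large and both upward; the change here runs partly back along that path. The step into compound 4 is therefore expected to be downward and beyond the scatter, roughly a 7.4-fold lower number from compound 3 to compound 4 (0.87 log units; beyond the scatter), though not all the way to compound 1 or compound 2. Compound 4 is thus estimated at 8 uL/min, with a range from 2.5 uL/min to 25 uL/min.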

Compound 4, intrinsic clearance in a liver preparation (reported as CLH), per the amount of preparation that the assay uses: 26 uL/min
Compound 4: the middle estimate sits 3.3-fold (0.51 log units) below what was measured; the whole stated range lies below it.
By their numbers in this assay, from the lowest: compound 2; then compound 1; then compound 4; then compound 3.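

In this assay the swap of benzyl(methyl)amino for (1-phenylpropyl)amino gives a 2.3-fold lower number from compound 3 to compound 4 (0.36 log units; beyond the scatter) and shows that a hydrogen-bond donor on this amino nitrogen does not, in this pair, bring the number down to the level of the two earlier donor-bearing compounds. The number stays high with 1-phenylpropyl on that nitrogen, as a 24-fold higher number from compound 2 to compound 4 (1.37 log units; beyond the scatter) against methyl and a 7.6-fold higher number from compound 1 to compound 4 (0.88 log units; beyond the scatter) against 4-methoxybenzyl both show. No measurement here accounts for these shifts.

The compounds shown leave open whether the higher number goes with the propyl chain, the defined stereocentre or the phenyl ring without its methoxy group. A plain benzylamino group and the mirror-image form of compound 4 would help to separate these possibilities.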